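Cytotoxicity notes on a diarylmethylamine series: hydroxy on the chain

A few compounds are considered here, and "the series" means these few. Any claim that something is new, unique, unknown or untested is made for them only; others in the source may bear on it.

Measured compounds:
compound 1, `CCNC(c1ccnc(Nc2ccc(C#N)cc2)n1)c1ccccc1Cl`, 39400 nM
compound 2, `CCCNC(c1ccnc(Nc2ccc(C#N)cc2)n1)c1ccccc1Cl`, 68500 nM
compound 3, `CCCNC(c1ccc(/C=C/C#N)cc1)c1ccnc(Nc2ccc(C#N)cc2)n1`, 34000 nM

In an ADME assay on MT4 cells (Homo sapiens) for cytotoxicity, read by MTT assay, with a stated time of 5 days (a lower number here means that less compound is tolerated, a higher number that more compound is tolerated), compound 2 gives the highest of the measured numbers, but its neighbours sit close: the step of a 1.7-fold higher number from compound 1 to compound 2 (0.24 log units; within the scatter) and the step of a 2.0-fold lower number from compound 2 to compound 3 (0.30 log units; within the scatter) both stay within the scatter, so no ordering among the measured compounds can be claimed.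

Compound 4, `CC(O)CNC(c1ccnc(Nc2ccc(C#N)cc2)n1)c1ccccc1Cl`, differs from compound 2 by hydroxy in place of hydrogen on a saturated chain carbon bound to two saturated chain carbons. Within the data shown here, no measured step introduces a hydroxy group; the only step touching the chain is a 1.7-fold higher number from compound 1 to compound 2 (0.24 log units; within the scatter), where a chain carbon is added without any shift beyond the scatter, and the aryl swap a 2.0-fold lower number from compound 2 to compound 3 (0.30 log units; within the scatter) is likewise flat. Nothing here points to a direction for this assay, so a change beyond the scatter is not expected.

The estimate for compound 4 in this assay is 55000 nM, with a range from 25000 nM to 130000 nM, which means the expected step of a 1.2-fold lower number from compound 2 to compound 4 (0.10 log units; within the scatter).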

Compound 4, half-maximal cytotoxic concentration: 34700 nM
Compound 4: the middle estimate sits 1.6-fold (0.20 log units) above what was measured; measured number inside the range.
By their numbers in this assay, from the lowest: compounds 3, 4, 1 and 2 (each within the scatter of the next).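

In this assay hydroxy in place of hydrogen on a saturated chain carbon bound to two saturated chain carbons gives a 2.0-fold lower number from compound 2 to compound 4 (0.30 log units; within the scatter) and so shows that this position carries a hydroxy group with no readable shift. Measured against the shorter chain, 1-hydroxyethyl in place of methyl on a saturated chain carbon bound to an amine nitrogen gives a 1.1-fold lower number from compound 1 to compound 4 (0.06 log units; within the scatter) and is just as flat, so neither route to compound 4 separates it from its neighbours. Nothing measured on these compounds speaks to the behaviour of the hydroxy group at this position.

As far as these compounds go, what an amine, a carboxylic acid or a methoxy group would give at this position remains open, as does a longer chain carrying the hydroxy group. Also open, from the compounds shown here alone, is whether the flat result holds when 4-(2-cyanoethenyl)phenyl, as in compound 3, replaces 2-chlorophenyl.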